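The source may report more compounds than this note shows. Statements on the series, on what has been measured and on what is new or still open speak of the compounds shown alone.

Compound 3 `COc1cc2ncnc(-n3nc(-c4ccccn4)nc3N)c2cc1OCCCCNC(=O)OC(C)(C)C` gives the lowest number of the three measured compounds in an assay on MCF7 cells for inhibition of Serine-protein kinase ATM (Homo sapiens), read by immunofluorescence, with a stated time of 1 h (on this read-out lower numbers stand for stronger inhibition and higher numbers for weaker inhibition), with 800 nM. Compound 2 `COc1cc2ncnc(-n3nc(-c4ccccn4)nc3N)c2cc1OCCCNC(=O)OC(C)(C)C` gives 900 nM, and compound 1 `CCN(CC)C(=O)COc1cc2c(-n3nc(-c4ccccn4)nc3N)ncnc2cc1OC` gives 5300 nM. The steps of a 5.9-fold lower number from compound 1 to compound 2 (0.77 log units; beyond the scatter) and a 6.6-fold lower number from compound 1 to compound 3 (0.82 log units; beyond the scatter) were modest but real, while a 1.1-fold lower number from compound 2 to compound 3 (0.05 log units; within the scatter) lay within the scatter, so lengthening the chain by one carbon changed little. Compound 4 `CCOC(=O)NCCCOc1cc2c(-n3nc(-c4ccccn4)nc3N)ncnc2cc1OC` differs from compound 3 by (ethoxycarbonyl)amino in place of ((tert-butoxycarbonyl)amino)methyl on a saturated chain carbon, three bonds along the chain from an oxygen on an aromatic ring, a smaller carbamate on a shorter chain. Because a 1.1-fold lower number from compound 2 to compound 3 (0.05 log units; within the scatter) showed chain length matters little, only a small effect is expected, and compound 4 is estimated to show a 1.4-fold higher number from compound 3 to compound 4 (0.14 log units; within the scatter) in this assay. Compound 4 is expected to give about 1100 nM, within a range of 500 nM to 2500 nM.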

Compound 4, half-maximal inhibitory concentration: 800 nM
The estimate for compound 4 lay 1.4-fold (0.14 log units) above the measured number; the measured number falls inside the stated range.
By their numbers in this assay, from the lowest: compounds 3, 4 and 2 (each within the scatter of the next); then compound 1.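

In this assay, among the compounds shown here, ethyl in place of tert-butyl on the carbamate oxygen, with the chain unchanged, gives a 1.1-fold lower number from compound 2 to compound 4 (0.05 log units; within the scatter) and so tests that end group alone for the first time, with no readable effect. Changing the end group and chain together gives no change at the digits printed from compound 3 to compound 4 (within the scatter) while the smaller carbamate keeps its distance from diethylcarbamoyl, with a 6.6-fold lower number from compound 1 to compound 4 (0.82 log units; beyond the scatter) as the step. No measurement at hand explains why these carbamates read alike.

Going by these compounds, whether a free amine or a carboxylic acid at the chain end would keep this number stays open.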